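Ethyl on the pyrazole nitrogen of compound 2

The source may hold more compounds than are shown below. What is called first, only, known or untested is meant among the compounds shown, and "the series" means these compounds.

Measured so far in an in vitro functional assay on cells (Fibroblast) for agonist activity at Alpha-1D adrenergic receptor (Homo sapiens); on this read-out higher numbers stand for an effect only at larger amounts of compound and lower numbers for an effect already at smaller amounts:
- compound 1 `Cc1n[nH]c(-c2ccccc2NCC2=NCCN2)n1`: < 5020 nM, a limit of the assay
- compound 2 `c1ccc(-c2cn[nH]c2)c(NCC2=NCCN2)c1`: 20 nM

Compound 2 holds the only number shown in this assay; the other value is a limit. Compound 1 gives only the limit of the assay, < 5020 nM, in this assay. The step that the limit leaves unreadable from compound 1 to compound 2 cannot be sized, as the limit of < 5020 nM in this assay, at which 1 of the 2 values shown sits, shows.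

Compound 3 `CCn1cc(-c2ccccc2NCC2=NCCN2)cn1` differs from compound 2 by ethyl in place of hydrogen on an aromatic nitrogen. For the measured compounds named here, none of the measured steps touches this aromatic nitrogen: the only measured step exchanges the whole five-membered ring and is unreadable anyway. Going by the values given here, no measured step therefore bears on the change, and nothing is known here about what an alkyl on that nitrogen does.

The expectation rests on compound 2 alone, with a wide range to cover the absent information. For compound 3 a value of 40 nM is expected, within 8 nM to 250 nM. The step of a 2.0-fold higher number from compound 2 to compound 3 (0.30 log units; within the scatter) is expected as the middle of this range, with no direction preferred beyond the scatter.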

Compound 3, half-maximal effective concentration: < 100000 nM
Compound 3 gave a limit, no number; the forecaster's own chance of this, stated with the estimate: 5%; the middle value does not contradict the limit.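

In this assay compound 3 gives only < 100000 nM, which is a limit of the assay and not a number. For the compounds shown here, no step from compound 2 to compound 3 can therefore be read. The compounds shown leave open whether ethyl in place of hydrogen on the aromatic nitrogen changes the read-out at all, and if so, in which direction and by how much.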